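Thiazole acetic acid series: aryl swap at the ring carbon

The source may report more compounds than this note shows. Statements on the series, on what has been measured and on what is new or still open speak of the compounds shown alone.

Compound 3 `O=C(O)Cc1sc(C(c2ccc(F)cc2)c2ccc(F)cc2)nc1-c1cccc(F)c1` is the reference point for this step. In an in vitro functional assay on HEK285-7 cells for antagonist activity at prostaglandin D2 receptor 2 (Homo sapiens), read by BRET and beta-arrestin recruitment (on this read-out lower numbers stand for smaller maximal responses and higher numbers for larger maximal responses), compound 3 gives 80%, level with compound 2 `O=C(O)Cc1sc(C(c2ccc(F)cc2)c2ccc(F)cc2)nc1-c1ccnc(N2CCC2)c1`, which in this assay gives 80%; together these two stand highest of the three numbers in hand. The smaller compound 1 `Nc1nc(-c2ccc(Cl)cc2)c(CC(=O)O)s1` sits furthest away and in this assay gives 50%, a gap to compound 3 that lies beyond the scatter.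

Compound 4 `O=C(O)Cc1sc(C(c2ccc(F)cc2)c2ccc(F)cc2)nc1-c1ccnc(O)c1` is not yet measured. The change from compound 3 is 2-hydroxypyridin-4-yl in place of 3-fluorophenyl on an aromatic carbon: a 2-hydroxypyridin-4-yl group enters where the 3-fluorophenyl group leaves, on the aromatic carbon of the five-membered ring next to the ring nitrogen and next to the ring atom that bears the carboxymethyl group.

Within the data shown here, one measured step bears directly on this, since it exchanges an aryl group at the same place: no change at the digits printed from compound 2 to compound 3 (within the scatter). That swap, between a 2-(azetidin-1-yl)pyridin-4-yl group and a 3-fluorophenyl group, moved the maximal response by nothing beyond the scatter. On that basis the step to a 2-hydroxypyridin-4-yl group is expected to produce no change beyond the scatter, no change at the digits printed from compound 3 to compound 4 (within the scatter), with no direction favoured.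

Compound 4 is therefore estimated at 80% in this assay, within a range of 65% to 95%.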

Compound 4, largest response reached (reported as efficacy), in percent of the reference or control that the assay uses: 60%
Compound 4: the middle estimate sits 20 percentage points above what was measured; the whole stated range lies above it.
By their numbers in this assay, from the lowest: compounds 1 and 4 (each within the scatter of the next); then compounds 2 and 3 (each within the scatter of the next).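

In this assay, the aryl group on the aromatic carbon next to the ring nitrogen is not freely exchangeable: 2-hydroxypyridin-4-yl in place of 3-fluorophenyl gives a number 20 percentage points lower from compound 3 to compound 4 (beyond the scatter), whereas the earlier aryl swap gave no change at the digits printed from compound 2 to compound 3 (within the scatter). The substituent on the pyridin-4-yl group also counts, since hydroxy in place of azetidin-1-yl gives a number 20 percentage points lower from compound 2 to compound 4 (beyond the scatter), so sharing a pyridin-4-yl group does not keep compound 4 level with compound 2. Nothing available explains this shift in maximal response.

The compounds shown leave open whether the hydroxy group itself accounts for the change, since a methoxy or amino group at the same ring position, or an unsubstituted pyridin-4-yl group, would be needed to separate the hydroxy group from the ring nitrogen. On these data alone, it is also open whether the same exchange would have a similar effect with a group other than bis(4-fluorophenyl)methyl on the shared core, such as a single 4-fluorobenzyl group.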